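From Ethylamino to Piperidinylmethyl on the Carbonyl Carbon

The compounds below may be only part of what the source reports. "The series", "measured", "known", "first", "only" and "open" are said of these compounds alone.

Compound 1 `CCNC(=O)Nc1cccc2c1CN(C)CC2c1ccccc1` was examined in a functional assay on the whole organism for inhibition of sodium-dependent dopamine transporter (Mus musculus); a higher number here means that more compound is needed for the effect, a lower number that less compound is needed. In this assay compound 1 gives only a limit, > 80 mg/kg, and no number. Two related compounds differ from it in one place. Compound 2 `CCCCOC(=O)Nc1cccc2c1CN(C)CC2c1ccccc1` carries butoxy in place of ethylamino on the carbonyl carbon and gives 12 mg/kg in this assay. Compound 3 `CN1Cc2c(NC(=O)OCc3ccccc3)cccc2C(c2ccccc2)C1` carries benzyloxy in place of ethylamino on the carbonyl carbon and gives 25 mg/kg in this assay. The steps from the parent are an at least 6.6-fold lower number from compound 1 to compound 2 (0.82 log units; beyond the scatter) and an at least 3.2-fold lower number from compound 1 to compound 3 (0.50 log units; beyond the scatter), and between the two measured compounds the step is a 2.1-fold higher number from compound 2 to compound 3 (0.32 log units; beyond the scatter). Compound 1 thus stands at the high end of what is shown, and the limit of > 80 mg/kg in this assay, at which 1 of the 3 values shown sits, means its distance from the others is known only as a bound.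

Compound 4 `CN1Cc2c(NC(=O)CN3CCCCC3)cccc2C(c2ccccc2)C1` differs from compound 1 as follows: (piperidin-1-yl)methyl in place of ethylamino on a carbonyl carbon. Both measured steps from compound 1 that exchange the ethylamino group lower the number by at least a modest margin, and on that basis a lower number is expected for compound 4 as well, though the entering group is unlike either of them, so the expectation is held loosely. The step is estimated as an at least 2.6-fold lower number from compound 1 to compound 4 (0.42 log units; beyond the scatter). Compound 4 is estimated to give 30 mg/kg in this assay, within a range from 8 mg/kg to 120 mg/kg.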

Compound 4, dose for half-maximal effect: about 60 mg/kg
Estimate against measurement, compound 4: 2.0-fold (0.30 log units) below, within the range that was stated.
By their numbers in this assay, from the lowest: compound 2; then compound 3; then compound 4. At a limit, above all of these: compound 1.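

Compound 4 is the only compound shown with a carbon-linked group on the carbonyl carbon, and this group does not match either oxygen-linked group. In this assay, (piperidin-1-yl)methyl in place of benzyloxy gives a 2.4-fold higher number from compound 3 to compound 4 (0.38 log units; beyond the scatter), and in place of butoxy it gives a 5.0-fold higher number from compound 2 to compound 4 (0.70 log units; beyond the scatter). In place of ethylamino it gives only a floor, an at least 1.3-fold lower number from compound 1 to compound 4 (0.12 log units; that floor lies within the scatter). This step cannot be read more closely, since compound 1 gives only a limit: the limit of > 80 mg/kg in this assay, at which 1 of the 4 values shown sits.

The compounds shown leave open whether the higher numbers go with the piperidine ring or with the carbon in place of oxygen on the carbonyl carbon. A pentyl group or a (morpholin-4-yl)methyl group at this place could separate the two, and whether ethylamino truly ranks above (piperidin-1-yl)methyl also remains unsettled.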